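Changing the drawn geometry of one double bond

The compounds below may be only part of what the source reports. "The series", "measured", "known", "first", "only" and "open" are said of these compounds alone.

Measured so far:
Compound 1, `C/C(C#Cc1ccc(CCC(=O)O)c(F)c1)=C/CO`: 427 nM
Compound 2, `C/C=C\C#Cc1ccc(CCC(=O)O)c(F)c1`: 47.9 nM
Compound 3, `O=C(O)CCc1ccc(C#CCc2ccccc2)cc1`: 389 nM

In a functional assay on 1321-N1 cells for agonist activity at Free fatty acid receptor 1 (Homo sapiens), read by calcium flux, with a stated time of 0.4 s (on this read-out lower numbers stand for an effect already at smaller amounts and higher numbers for an effect only at larger amounts of compound), compound 2 gives the lowest of the three numbers, with compound 3 and compound 1 both lying well beyond the scatter above it. Within the data shown here, the one step measured so far, an 8.9-fold lower number from compound 1 to compound 2 (0.95 log units; beyond the scatter), shows that trimming the group on the triple-bonded carbon to a plain prop-1-en-1-yl brought a clear gain.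

Compound 4, `C/C=C/C#Cc1ccc(CCC(=O)O)c(F)c1`, keeps every atom and bond of compound 2: the two compounds have the same atoms and bonds and differ only in configuration as drawn: 1 of 1 stereo elements differ; a double bond is drawn Z in compound 2 and E in compound 4. Among the measured compounds shown here, none of the measured steps changes only the drawn configuration of a double bond, so there is no direct precedent for this move, and the step from compound 1 to compound 2 speaks only to the size of the side chain, not to its geometry. With the same atoms in place, the most defensible expectation is a number close to that of compound 2, with some chance of a modest shift in either direction. For compound 4 the estimate is therefore 80 nM (range 25 nM to 250 nM), which would be a step of a 1.7-fold higher number from compound 2 to compound 4 (0.22 log units; within the scatter) that is expected to stay near the scatter.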

Compound 4, half-maximal effective concentration: 209 nM
Compound 4: middle estimate off by 2.6-fold (0.42 log units), on the low side; low and high end bracket the measured number.
By their numbers in this assay, from the lowest: compound 2; then compounds 4, 3 and 1 (each within the scatter of the next, the first and the last beyond it).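

The drawn geometry of this one double bond counts on its own in this assay, with a 4.4-fold higher number from compound 2 to compound 4 (0.64 log units; beyond the scatter), and the whole of that step traces to one thing: the fact that compounds 2 and 4 differ only in the configuration as drawn. This also changes how the earlier step reads, since the gain from trimming the side chain depends on the geometry of the trimmed product. That trim gives an 8.9-fold lower number from compound 1 to compound 2 (0.95 log units; beyond the scatter) when the double bond is drawn Z, but only a 2.0-fold lower number from compound 1 to compound 4 (0.31 log units; beyond the scatter) when it is drawn E.

As far as these compounds go, it remains open whether the same gap between Z and E would hold if the prop-1-en-1-yl group gave way to a longer chain or to a chain carrying an amine. Also open, from the compounds shown here alone, is whether the 3-hydroxy-1-methylprop-1-en-1-yl group of compound 1 would respond in the same way to a change of geometry.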